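The source may hold more compounds than are shown below. What is called first, only, known or untested is meant among the compounds shown, and "the series" means these compounds.

Of the compounds shown here, three have been measured in a functional assay on MT4 cells (Homo sapiens) for antiproliferative activity, read by MTT assay, with a stated time of 96 h; a higher number here means that more compound is needed for the effect, a lower number that less compound is needed. Compound 1 `CCOC(=O)/C(=C/c1c(-c2ccccc2)[nH]c2ccccc12)C(=O)c1ccc([N+](=O)[O-])cc1` gives 1500 nM in this assay. Compound 2 `Cc1ccc(S(=O)(=O)/C(C#N)=C/c2c(-c3ccccc3)[nH]c3ccccc23)cc1` gives 400 nM. Compound 3 `N#CC(C#N)=Cc1c[nH]c2ccccc12`, a smaller molecule with two nitriles, gives 36000 nM. Compound 2 therefore stands lowest of the three numbers, meaning the least compound is needed for the effect; compound 1 sits beyond the scatter above it, and compound 3 lies further still.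

Compound 4 `N#C/C(=C\c1c(-c2ccccc2)[nH]c2ccccc12)S(=O)(=O)c1ccccc1` has not yet been measured. It differs from compound 2 in one place: hydrogen in place of methyl on an aromatic carbon. Among the measured compounds shown here, no pair of measured compounds shows the effect of exactly this change, so nothing in the data fixes its size. The change removes only a methyl at the outer edge of the molecule, and the usual expectation for a change of this kind is a small step at most: either a slight move toward a higher number or no step beyond the scatter. On that basis the step from compound 2 to compound 4 is expected to be a 1.3-fold higher number from compound 2 to compound 4 (0.10 log units; within the scatter). Compound 4 is thus expected to give 500 nM in this assay, with a range from 200 nM to 1500 nM.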

Compound 4, half-maximal effective concentration: 400 nM
Estimate against measurement, compound 4: 1.3-fold (0.10 log units) above; the range from low to high includes it.
By their numbers in this assay, from the lowest: compounds 2 and 4 (each within the scatter of the next); then compound 1; then compound 3.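

In this assay, among the compounds shown here, taking away the methyl on the aromatic carbon, so that 4-methylphenyl becomes phenyl, gives no change at the digits printed from compound 2 to compound 4 (within the scatter) and adds the first direct comparison of a single change to this set. The comparison shows that, in this assay, the methyl at this position is not required for the activity of compound 2: compound 4 lacks the group, yet its value is not separated from that of compound 2. Nothing measured here bears on why the two compounds read alike.

Going by these compounds, a comparison of methyl with hydrogen cannot show whether this position would tolerate other groups, so the effect of a methoxy group, an amine or a carboxylic acid in the same place remains open. On these data alone, compound 1 and compound 3 each differ from compound 2 and compound 4 in more than one place, so their steps cannot be read, and it remains open which other parts of these molecules matter for the values in this assay.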